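The compounds below may be only part of what the source reports. "The series", "measured", "known", "first", "only" and "open" are said of these compounds alone.

Working notes on the series. In a functional assay on Raji cells (Homo sapiens) for cytotoxicity, read by CCK-8 assay, with a stated time of 24 h (a higher number here means a weaker inhibitor, a lower number a stronger inhibitor), compound 1 `C=CC(=O)N1C(=O)CC(C)Sc2ccccc21` gives 837000 nM and compound 2 `C=CC(=O)N1C(=O)CC(c2cccs2)Sc2ccccc21` gives 659000 nM. Going by the values given here, the only measured step between them is a 1.3-fold lower number from compound 1 to compound 2 (0.10 log units; within the scatter), so the two numbers set no order, and compound 2 stands level with compound 1.

The next compound is compound 3 `C=CC(=O)N1C(=O)CC(c2cccc(Cl)c2)Sc2ccccc21`, which has 3-chlorophenyl in place of thiophen-2-yl on a saturated ring carbon, next to the ring sulfur: 3-chlorophenyl in place of thiophen-2-yl on a saturated ring carbon. Among the compounds with values here, the same carbon carries the change in the measured step, so that step is the one piece of evidence bearing on this swap. Within the data shown here, it is thin evidence, as no measured compound carries 3-chlorophenyl and a single step shows no trend.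

Among the measured compounds shown here, because the one measured change at this carbon was a 1.3-fold lower number from compound 1 to compound 2 (0.10 log units; within the scatter) no step beyond the scatter is expected in this assay, and no direction is favoured with any confidence. For compound 3 the estimated step is a 1.3-fold lower number from compound 2 to compound 3 (0.12 log units; within the scatter), which is expected to stay small. Compound 3 is expected to give about 500000 nM, with an estimated range of 170000 nM to 1100000 nM.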

Compound 3, half-maximal inhibitory concentration: 47100 nM
Estimate against measurement, compound 3: 11-fold (1.03 log units) above; measured number outside the range, below it.
By their numbers in this assay, from the lowest: compound 3; then compounds 2 and 1 (each within the scatter of the next).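

In this assay this saturated ring carbon, next to the ring sulfur, proves sensitive to the group it carries: 3-chlorophenyl in place of thiophen-2-yl gives a 14-fold lower number from compound 2 to compound 3 (1.15 log units; beyond the scatter), and 3-chlorophenyl in place of methyl gives an 18-fold lower number from compound 1 to compound 3 (1.25 log units; beyond the scatter). The earlier change from methyl to thiophen-2-yl stayed within the scatter, so an aromatic ring at this carbon does not by itself bring a large step: thiophen-2-yl goes against any such reading, and only 3-chlorophenyl stands apart from the other two groups. Nothing available bears on why the number falls with this group.

The compounds shown leave open whether the step belongs to the chlorine or to the six-membered carbon ring, a question that a plain phenyl group at this carbon would address. They also leave open how far the step extends to other groups on that ring, such as fluorine, methoxy or an amine in place of the chlorine, and whether any of these would take the number lower than in compound 3.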